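The source may hold more compounds than are shown below. What is called first, only, known or untested is meant among the compounds shown, and "the series" means these compounds.

Measured in a functional assay on a cell-free system (plasma, Oryctolagus cuniculus) for inhibition, with stated times of 5 min, 1 min and 6 min; a lower number here means a stronger inhibitor, a higher number a weaker inhibitor:
- compound 1 `CCOC(=O)c1c(C)nc(-c2cccc(C#N)c2)n1OCc1cccc(Cl)c1`: 19400 nM
- compound 2 `CCOC(=O)c1c(C)nc(-c2cccc(C#N)c2)n1OCc1ccc(C)cc1`: 6310 nM

Compound 2, at 6310 nM, has the lower of the two numbers in this assay and is the stronger inhibitor of the pair. The next structure, compound 3 `CCOC(=O)c1c(C)nc(-c2cccc(C#N)c2)n1OCc1ccc([N+](=O)[O-])cc1`, follows from compound 2 by one change: nitro in place of methyl on an aromatic carbon. This places nitro in place of methyl on an aromatic carbon, para to a large group.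

Among the measured compounds shown here, only one measured step bears on this change: a 3.1-fold lower number from compound 1 to compound 2 (0.49 log units; beyond the scatter). It is modest, lies beyond the scatter and swaps 4-methylphenyl in place of 3-chlorophenyl. For the measured compounds named here, no nitro compound has been measured, so this step is a rough guide to size and a weak guide to direction. A modest rise in the number is expected, with a fall not excluded. The estimated step is a 1.7-fold higher number from compound 2 to compound 3 (0.24 log units; within the scatter). Compound 3 is expected at 11000 nM, with an estimated range of 3500 nM to 32000 nM.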

Compound 3, half-maximal inhibitory concentration: 8750 nM
Compound 3: middle estimate off by 1.3-fold (0.10 log units), on the high side; the range from low to high includes it.
By their numbers in this assay, from the lowest: compounds 2 and 3 (each within the scatter of the next); then compound 1.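

In this assay, nitro in place of methyl on an aromatic carbon, para to a large group, gives a 1.4-fold higher number from compound 2 to compound 3 (0.14 log units; within the scatter), so this position accepts either group without a change that can be read beyond the scatter. The other new comparison, 4-nitrophenyl in place of 3-chlorophenyl, gives a 2.2-fold lower number from compound 1 to compound 3 (0.35 log units; beyond the scatter); this matches the earlier finding for 4-methylphenyl, but each of these steps alters both the group and where it sits, and the two effects cannot be separated. No available evidence accounts for these numbers.

Going by these compounds, whether 4-chlorophenyl would fall with compound 2 and compound 3 or with compound 1 remains open. Also open, on these data alone, is how an amine or a carboxylic acid would read at this position.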